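The source may hold more compounds than are shown below. What is called first, only, known or untested is meant among the compounds shown, and "the series" means these compounds.

Measured compounds:
- compound 1, `CCC(CC)(CC)C(=O)O[C@H]1C[C@@H](C)C=C2C=C[C@H](C)[C@H](CC[C@@H]3C[C@@H](O)CC(=O)O3)C21`, 1.4 nM
- compound 2, `C[C@H]1C=C2C=C[C@H](C)[C@H](CC[C@@H]3C[C@@H](O)CC(=O)O3)C2[C@@H](OC(=O)C(C)(C)C)C1`, 2.7 nM

In an assay for inhibition of 3-hydroxy-3-methylglutaryl-coenzyme A reductase (Rattus norvegicus) (on this read-out higher numbers stand for weaker inhibition and lower numbers for stronger inhibition), compound 1 gives 1.4 nM and compound 2 gives 2.7 nM. Compound 2 holds the higher of the two numbers, but its step from compound 1 is within the scatter, so the two are not ordered: a 1.9-fold higher number from compound 1 to compound 2 (0.29 log units; within the scatter).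

Compound 3, `CCCC(CC)(CC)C(=O)O[C@H]1C[C@@H](C)C=C2C=C[C@H](C)[C@H](CC[C@@H]3C[C@@H](O)CC(=O)O3)C21`, has not yet been run in this assay. It differs from compound 2 in one place: 1,1-diethylbutyl in place of tert-butyl on a carbonyl carbon. This largely undoes the step from compound 1 to compound 2, with one more carbon in the chain entering than was present in compound 1. That step is the only one in the series that bears on the change, and it stayed within the scatter: a 1.9-fold higher number from compound 1 to compound 2 (0.29 log units; within the scatter). No step beyond the scatter is therefore expected for compound 3 in this assay, and the number is expected to sit near that of compound 1, because of 1.4 nM.

For compound 3 in this assay the estimated value is 1.5 nM, with a range from 0.6 nM to 4 nM. The expected step is a 1.8-fold lower number from compound 2 to compound 3 (0.26 log units; within the scatter), which is within the scatter.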

Compound 3, half-maximal inhibitory concentration: 1.9 nM
Beside the measured number, compound 3's estimate is 1.3-fold (0.10 log units) below it, within the range that was stated.
By their numbers in this assay, from the lowest: compounds 1, 3 and 2 (each within the scatter of the next).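

In this assay, putting 1,1-diethylbutyl in place of tert-butyl on the carbonyl carbon gives a 1.4-fold lower number from compound 2 to compound 3 (0.15 log units; within the scatter) and stays within the scatter, even though the group entering has 8 heavy atoms and the one leaving has 4. The smaller change, methyl in place of hydrogen on a saturated chain carbon, gives a 1.4-fold higher number from compound 1 to compound 3 (0.13 log units; within the scatter) and is also within the scatter, so neither step orders the compounds. Tert-butyl, 1,1-diethylpropyl and 1,1-diethylbutyl therefore cannot be told apart at this position by this read-out, which extends the single earlier step to a larger all-carbon group, and no supporting data are available to explain this flat result.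

On these data alone, all three groups are saturated, acyclic and made only of carbon, so it remains open whether the flat result would hold for a much smaller group such as methyl, a longer chain, or a group carrying a phenyl ring. As far as these compounds go, it is equally open whether an amine or a carboxylic acid at the end of such a chain would produce a step beyond the scatter.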